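Methoxy for chloro on two related cores: cell toxicity

A few compounds are considered here, and "the series" means these few. Any claim that something is new, unique, unknown or untested is made for them only; others in the source may bear on it.

Three compounds have been measured in a functional assay on FaDu cells (Homo sapiens) for cytotoxicity, read by MTT assay, with a stated time of 72 h; on this read-out higher numbers stand for lower toxicity in this test and lower numbers for higher toxicity in this test:

compound 1 `COc1ccc(NC(=O)C(=O)c2cn(C(C)C)c3c(Cl)cccc23)cn1`: 10200 nM
compound 2 `COCCn1cc(C(=O)C(=O)Nc2ccc(OC)nc2)c2cc(Cl)ccc21`: > 10000 nM, a limit of the test, not a number
compound 3 `COc1ccc(NC(=O)C(=O)c2cn(C(C)C)c3c(OC)cccc23)cn1`: > 10000 nM, again a limit, not a number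

Compound 1 and compound 2 differ in more than one place; how their cores differ is not broken down here. From compound 1 to compound 3 the change is methoxy in place of chloro on an aromatic carbon. The step that the limit leaves unreadable from compound 1 to compound 3 cannot be sized because the limit of > 10000 nM in this assay, at which 2 of the 3 values shown sit, hides its end. Compound 4 `COCCn1cc(C(=O)C(=O)Nc2ccc(OC)nc2)c2cc(OC)ccc21` is not yet measured. It differs from compound 2 by methoxy in place of chloro on an aromatic carbon, the same kind of change, though the place is not identical: ortho to a fused ring and meta to a fused ring in the first pair, meta to a fused ring and para to a fused ring here. Resting on compound 2 sitting at the limit of > 10000 nM in this assay, at which 2 of the 3 values shown sit, compound 4 is expected to give 15000 nM, between 7000 nM and 40000 nM. The expected step is a step that the limit leaves unreadable from compound 2 to compound 4, most likely again only a limit.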

Compound 4, concentration lethal to 50% of the cells: > 10000 nM
Compound 4: no number, only a limit; the forecaster's own chance of this, stated with the estimate: 80%; the middle value is on the limit's open side.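

No step can be read from compound 2 to compound 4, because both stop at a limit of the test and give no number: the limit of > 10000 nM in this assay, at which 3 of the 4 values shown sit.

On these data alone, how far methoxy in place of chloro moves the result in this assay on either core stays open.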